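The source may report more compounds than this note shows. Statements on the series, on what has been measured and on what is new or still open speak of the compounds shown alone.

Compound 2 `Cc1cccc(C)c1Oc1nc(Nc2ccc(C#N)cc2)nc2ccccc12` and compound 1 `N#Cc1ccc(Nc2nc(Oc3ccccc3Cl)c3ccccc3n2)cc1` share one core and differ only in the ring attached to an oxygen on an aromatic ring. In an ADME assay on MT4 cells (Homo sapiens) for cytotoxicity, read by MTT assay, with a stated time of 4 days (a higher number here means that more compound is tolerated, a lower number that less compound is tolerated), compound 1 gives 38000 nM, and in this assay compound 2 gives 35000 nM; the step of a 1.1-fold lower number from compound 1 to compound 2 (0.04 log units; within the scatter) shows that the two lie within the scatter of each other, so neither can be called better tolerated than the other. Compound 3 `Cc1cc(Br)cc(Br)c1Oc1nc(Nc2ccc(C#N)cc2)nc2ccccc12` has not yet been measured; it differs from compound 2 by 2,4-dibromo-6-methylphenyl in place of 2,6-dimethylphenyl on an oxygen on an aromatic ring. Among the compounds with values here, only one measured step bears on this change: it also swapped the ring at the same place, and it gave a 1.1-fold lower number from compound 1 to compound 2 (0.04 log units; within the scatter). On that basis the number for compound 3 is expected to stay close to that of compound 2, with an expected step of a 1.1-fold lower number from compound 2 to compound 3 (0.03 log units; within the scatter). Compound 3 is therefore estimated at 33000 nM, with a range from 14000 nM to 80000 nM.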

Compound 3, half-maximal cytotoxic concentration: 150000 nM
Compound 3: the middle estimate sits 4.5-fold (0.66 log units) below what was measured; measured number above the stated range.
By their numbers in this assay, from the lowest: compounds 2 and 1 (each within the scatter of the next); then compound 3.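

Until now, swapping the ring on the oxygen had produced no change beyond the scatter in this assay, so this position could have looked indifferent to the choice of ring. The 2,4-dibromo-6-methylphenyl group changes that picture, giving a 4.3-fold higher number from compound 2 to compound 3 (0.63 log units; beyond the scatter) and also a 3.9-fold higher number from compound 1 to compound 3 (0.60 log units; beyond the scatter), so the ring at this place can raise the amount of compound the cells tolerate, although both steps are only modest. No measurement is available to explain why this ring stands apart from the other two. The two bromine atoms enter together in a single change, so the compounds shown cannot tell what each contributes alone. Also open, from the compounds shown here alone, is how the number would move with a ring carrying an amine or a carboxylic acid at this place.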